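The compounds below may be only part of what the source reports. "The series", "measured", "known", "first", "only" and "open" are said of these compounds alone.

Measured compounds:
Compound 1 `C=CCn1c(=O)/c(=C\c2ccc(Cl)c(Cl)c2)[nH]c(=O)/c1=C\c1ccccc1`: "not active" (no number reported)
Compound 2 `COc1ccccc1/C=c1\c(=O)[nH]/c(=C/c2ccccc2Cl)c(=O)n1C`: 300 nM
Compound 3 `C=CCn1c(=O)/c(=C\c2cc(OC)c(OC)c(OC)c2)[nH]c(=O)/c1=C\c1cccc(Br)c1`: "not active" (no number reported)

Among the measured compounds shown here, in a functional assay on Huh-7 cells (Homo sapiens) for cytotoxicity, read by CCK-8 assay, with a stated time of 72 h (on this read-out lower numbers stand for stronger inhibition and higher numbers for weaker inhibition), compound 2 gives 300 nM, and it is the only compound of the three for which a number is reported at all. Compound 1 gives "not active" (no number reported) in this assay, and compound 3 likewise gives "not active" (no number reported), so neither offers a number against which compound 2 could be ranked. For the measured compounds named here, no pair of measured compounds differs in one place, so no step size within this set can be read off directly.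

Compound 4 `COc1ccccc1/C=c1/[nH]c(=O)/c(=C\c2ccccc2OC)n(C)c1=O` has not yet been measured in this assay. It differs from compound 2 by methoxy in place of chloro on an aromatic carbon, so both aromatic rings of compound 4 carry the same methoxy group. With two of three measured compounds reporting no number, the expectation for compound 4 is cautious: a step within the scatter or somewhat toward weaker inhibition in this assay is expected rather than a large move, with a real chance that no number is reported. The estimated step from compound 2 to compound 4 is a 2.0-fold higher number from compound 2 to compound 4 (0.30 log units; within the scatter). Compound 4 is expected to give about 600 nM in this assay, in a range from 150 nM to 4000 nM.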

Compound 4, half-maximal inhibitory concentration: "not active" (no number reported)
Nothing numeric was reported for compound 4; there is nothing to compare the estimate with.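

In this assay compound 2 gives 300 nM and compound 4 gives "not active" (no number reported) so no step can be read between these two compounds. The compounds shown leave open how far the change from 2-chlorophenyl to 2-methoxyphenyl shifts the read-out. No measured evidence bears on this result.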